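Swapping the Benzimidazole Arm on a Shared Core

The source may report more compounds than this note shows. Statements on the series, on what has been measured and on what is new or still open speak of the compounds shown alone.

Three compounds share one core and differ only in the aromatic group attached to it. Compound 1 `Cn1ncc2cc(-c3cnc4[nH]ccc4c3N3CCC4(CCNC4=O)CC3)ccc21` gives 7 nM in an assay on cells for binding affinity to Cyclin-C/Cyclin-dependent kinase 19 (Homo sapiens), read by LanthaScreen; a lower number here means a stronger inhibitor, a higher number a weaker inhibitor. Compound 2 `O=C1NCCC12CCN(c1c(-c3ccc4ncsc4c3)cnc3[nH]ccc13)CC2` gives 80 nM, and compound 3 `Cn1cnc2cc(-c3cnc4[nH]ccc4c3N3CCC4(CCNC4=O)CC3)ccc21` gives 50 nM. Compound 3 thus holds the second highest of the three numbers: its nearest neighbour is compound 2, a gap that lies within the scatter, while compound 1 lies furthest away, beyond the scatter. The measured steps show how much this aromatic group matters: an 11-fold higher number from compound 1 to compound 2 (1.06 log units; beyond the scatter) and a 7.1-fold higher number from compound 1 to compound 3 (0.85 log units; beyond the scatter), whereas a 1.6-fold lower number from compound 2 to compound 3 (0.20 log units; within the scatter) stays within the scatter.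

Compound 4 `O=C1NCCC12CCN(c1c(-c3ccc4ncnn4c3)cnc3[nH]ccc13)CC2` has not been measured. It differs from compound 3 in one place: a group of 9 heavy atoms (6 carbon, 3 nitrogen; one five-membered aromatic ring with 3 hetero atoms, one six-membered aromatic ring with 1 hetero atom) in place of a group of 10 heavy atoms (8 carbon, 2 nitrogen; one five-membered aromatic ring with 2 hetero atoms, one six-membered aromatic ring of carbon only), on an aromatic carbon. Going by the values given here, both steps away from compound 1 at this position were losses, modest to large, and the step between compound 2 and compound 3 was flat, so a further change at the same place could move the number either way, with no close precedent to favour one direction. Compound 4 is therefore expected to show a step of a 1.4-fold higher number from compound 3 to compound 4 (0.15 log units; within the scatter), within the scatter. The estimate for compound 4 in this assay is 70 nM, with a range from 20 nM to 250 nM.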

Compound 4, half-maximal inhibitory concentration: 1020 nM
The estimate for compound 4 lay 15-fold (1.16 log units) below the measured number; measured number above the stated range.
By their numbers in this assay, from the lowest: compound 1; then compounds 3 and 2 (each within the scatter of the next); then compound 4.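

Compound 4 shows that this position can cost far more than the earlier swaps suggested: in this assay, the change gives a 20-fold higher number from compound 3 to compound 4 (1.31 log units; beyond the scatter), and the span measured at this position grows to a 150-fold higher number from compound 1 to compound 4 (2.16 log units; beyond the scatter). Heavy-atom count does not separate the result, as the 1,3-benzothiazol-6-yl group also has 9 heavy atoms, yet the change from that group gives a 13-fold higher number from compound 2 to compound 4 (1.11 log units; beyond the scatter); what sets the entering group apart among the four is a nitrogen in its six-membered aromatic ring and 3 hetero atoms in its five-membered aromatic ring. Nothing available here explains why the number rises so sharply with this group.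

The two ring differences arrive together in compound 4, so the compounds shown leave open whether one of them alone carries the loss or both are needed. An imidazopyridine group, with a nitrogen in the six-membered ring but one hetero atom fewer in the five-membered ring than the group in compound 4, would begin to separate the two.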